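A few compounds are considered here, and "the series" means these few. Any claim that something is new, unique, unknown or untested is made for them only; others in the source may bear on it.

In a functional assay on NCI-H460 cells (Homo sapiens) for cytotoxicity, read by MTT assay (on this read-out higher numbers stand for weaker inhibition and lower numbers for stronger inhibition), compound 1 `Cc1ccccc1Nc1nc(C)c(C(=O)/C=C/c2ccccc2Cl)s1` reaches only the limit of > 25000 nM and no number. Compound 2 `Cc1ccc(Nc2nc(C)c(C(=O)/C=C/c3ccccc3)s2)cc1` likewise stops at the limit of > 25000 nM in this assay. Compound 2 thus stands at the limit of > 25000 nM in this assay, at which 2 of the 2 values shown sit. Compound 3 `Cc1ccccc1Nc1nc(C)c(C(=O)/C=C/c2ccccc2)s1` differs from compound 2 by 2-methylphenyl in place of 4-methylphenyl on a nitrogen on an aromatic ring. For the measured compounds named here, no measured step joins the two, and compound 1, which already carries 2-methylphenyl, also gives only a limit. The step in this assay is expected to be no larger than the scatter, in neither direction, a step that the limit leaves unreadable from compound 2 to compound 3. Compound 3 is therefore estimated at 30000 nM, between 10000 nM and 100000 nM, most likely as a limit once more.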

Compound 3, half-maximal inhibitory concentration: > 25000 nM
Compound 3 ended at the assay's limit (the forecaster's own chance of this, stated with the estimate: 85%); the middle value does not contradict the limit.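

No step can be read from compound 2 or compound 1 to compound 3, as all three stop at one limit: the limit of > 25000 nM in this assay, at which 3 of the 3 values shown sit. The compounds shown leave open whether 2-methylphenyl versus 4-methylphenyl, or chloro versus hydrogen, makes any difference.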